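The source may report more compounds than this note shows. Statements on the series, on what has been measured and on what is new or still open speak of the compounds shown alone.

Measured so far in a functional assay on HepG2 cells (Homo sapiens) for inhibition, read by fluorescence and resazurin assay, with a stated time of 72 h; a higher number here means a weaker inhibitor, a lower number a stronger inhibitor:

- Compound 1 `O=C(Nc1ccccc1)Nc1cccc(Nc2nccc(Nc3ccc4nc[nH]c4c3)n2)c1`: 11000 nM
- Compound 2 `O=C1NC(Cc2ccc(Nc3nccc(Nc4ccc5cn[nH]c5c4)n3)cc2)CO1`: 20000 nM
- Compound 3 `O=C(Nc1ccc(F)cc1)Nc1cccc(Nc2nccc(Nc3ccc4cn[nH]c4c3)n2)c1`: 12000 nM

Compound 3 is the starting point here. At 12000 nM, compound 3 lies within the usual scatter of both compound 1 and compound 2, so the numbers do not separate it from either one. Repeat measurements of the same compound could differ by as much as these gaps.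

The next compound, compound 4 `Cc1cccc(NC(=O)Nc2cccc(Nc3nccc(Nc4ccc5cn[nH]c5c4)n3)c2)c1`, has not yet been measured. It carries 3-methylphenyl in place of 4-fluorophenyl on an amide-type nitrogen. The rest of the structure matches compound 3.

Among the compounds with values here, no two measured compounds differ in only one place, so no direct comparison shows what a single swap does in this assay. Within the data shown here, the only guide is the narrow spread of the values, even though the structures differ in more than one place. With so little evidence, no direction can be argued for this change. The estimated step of a 1.1-fold lower number from compound 3 to compound 4 (0.04 log units; within the scatter) is expected to stay within the scatter. The expected value for compound 4 is 11000 nM, with an estimated range from 5000 nM to 25000 nM.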

Compound 4, half-maximal inhibitory concentration: 2800 nM
Beside the measured number, compound 4's estimate is 3.9-fold (0.59 log units) above it, outside the stated range (below it).
By their numbers in this assay, from the lowest: compound 4; then compounds 1, 3 and 2 (each within the scatter of the next).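

In this assay, within the data shown here, the change on the amide-type nitrogen gives a 4.3-fold lower number from compound 3 to compound 4 (0.63 log units; beyond the scatter) and provides the first single-place comparison in this set, a step beyond the scatter. It shows that this position is not indifferent to the group it carries: 4-fluorophenyl and 3-methylphenyl have the same count of heavy atoms, the same kind of ring, no hydrogen-bond donors or acceptors and no net charge, yet their values differ, so those shared counts do not settle the outcome here. Nothing available explains why these two groups give different values.

Because the fluorine and the methyl also sit at different places on the ring, this single step cannot show whether the identity of the group, its place or both account for the difference. Also open, on these data alone, is how the value would respond to a chlorine atom, a methoxy group or an amine on that ring, and whether the same swap would give a similar step on another core.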